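Swapping the basic amine ring on a urea series

The source may hold more compounds than are shown below. What is called first, only, known or untested is meant among the compounds shown, and "the series" means these compounds.

Measured so far:
- Compound 1, `CN(C)CCN(C(=O)Nc1cc(Cl)cc(Cl)c1)c1ccc(-c2cccc(C#N)c2)cc1`: 19 nM
- Compound 2, `CN(C)CCN(C(=O)Nc1ccc(C(F)(F)F)c(F)c1)c1ccc(-c2cccc(C#N)c2)cc1`: 6 nM
- Compound 3, `N#Cc1cccc(-c2ccc(N(CCN3CCCC3)C(=O)Nc3ccc(C(F)(F)F)c(F)c3)cc2)c1`: 5.6 nM

All three were tested in an assay on isolated protein for inhibition of melanin-concentrating hormone receptor 1 (Homo sapiens); on this read-out lower numbers stand for stronger inhibition and higher numbers for weaker inhibition. Compound 3 has the lowest of the three numbers, but compound 2 lies within the usual scatter of it, so the two cannot be told apart; only compound 1 stands clearly apart, with a 3.2-fold lower number from compound 1 to compound 2 (0.50 log units; beyond the scatter). That step came from changing the aryl group on the urea nitrogen and says nothing about the amine end of the chain. The step that does bear on the amine end is a 1.1-fold lower number from compound 2 to compound 3 (0.03 log units; within the scatter), which fell within the scatter.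

Compound 4, `CN1CCN(CCN(C(=O)Nc2ccc(C(F)(F)F)c(F)c2)c2ccc(-c3cccc(C#N)c3)cc2)CC1`, has not yet been measured. It differs from compound 3 in one place: 4-methylpiperazin-1-yl in place of pyrrolidin-1-yl on a saturated chain carbon, two bonds along the chain from an amide-type nitrogen. Among the compounds with values here, this is again a change of the amine at the same position where the earlier exchange produced no clear shift, so for compound 4 in this assay the expected step is a 1.3-fold higher number from compound 3 to compound 4 (0.10 log units; within the scatter), essentially no change beyond the scatter, because the only comparable step was a 1.1-fold lower number from compound 2 to compound 3 (0.03 log units; within the scatter). Compound 4 is therefore estimated at 7 nM, in the range from 2.5 nM to 20 nM.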

Compound 4, inhibition constant: 8.2 nM
Compound 4: the middle estimate sits 1.2-fold (0.07 log units) below what was measured, and the stated range covers the measured number.
By their numbers in this assay, from the lowest: compounds 3, 2 and 4 (each within the scatter of the next); then compound 1.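

In this assay, the 4-methylpiperazin-1-yl group puts a six-membered ring with 2 hetero atoms at this place on the chain, with 7 heavy atoms and 2 hydrogen-bond acceptors against 5 heavy atoms and 1 hydrogen-bond acceptor in pyrrolidin-1-yl, and the outcome is a 1.5-fold higher number from compound 3 to compound 4 (0.17 log units; within the scatter) and so no readable change. Against the dimethylamino group the picture is the same, with a 1.4-fold higher number from compound 2 to compound 4 (0.14 log units; within the scatter) as the step. With the 3-fluoro-4-(trifluoromethyl)phenyl group held fixed, the three amines in compound 2, compound 3 and compound 4 therefore cannot be told apart on this read-out, so the larger ring is accepted as readily as the two earlier amines, and no measurement on hand explains this evenness.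

Still open, going by these compounds, is how far this tolerance reaches: a carboxylic acid in place of the amine, or a morpholin-4-yl ring, could show whether the number depends on the second ring nitrogen or on the amine at all. A longer chain, such as 3-(pyrrolidin-1-yl)propyl in place of 2-(pyrrolidin-1-yl)ethyl, would probe a different question, and every compound shown keeps the amine on the same ethyl chain.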